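Two Chlorines for a Methoxy on the Benzyloxy Arm

The source may hold more compounds than are shown below. What is called first, only, known or untested is meant among the compounds shown, and "the series" means these compounds.

Measured compounds in an assay on HepG2 cells for agonist activity at nuclear receptor subfamily 1 group I member 3 (Homo sapiens), read by a luciferase reporter, with a stated time of 23 h; a lower number here means that less compound is needed, a higher number that more compound is needed for the effect:
Compound 1 `COc1ccc(CO/N=C/c2c(-c3ccc4ccccc4c3)nc3occn23)cc1`: 4400 nM
Compound 2 `Clc1ccc(CO/N=C/c2c(-c3cccc4ccccc34)nc3sccn23)cc1Cl`: 940 nM
Compound 3 `Clc1ccc(CO/N=C/c2c(-c3ccc(Br)cc3)nc3sccn23)cc1Cl`: 480 nM

Compound 1 gives the highest number of the three in this assay; compound 2 sits closer to it and compound 3 furthest, both gaps lying beyond the scatter. For the measured compounds named here, the one step that can be read within one change, a 2.0-fold lower number from compound 2 to compound 3 (0.29 log units; within the scatter), concerns the aryl group on the core and not the benzyloxy arm, so it does not bear directly on the change at hand.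

Compound 4 `Clc1ccc(CO/N=C/c2c(-c3ccc4ccccc4c3)nc3occn23)c(Cl)c1` differs from compound 1 in that arm: 2,4-dichlorophenyl in place of 4-methoxyphenyl on a saturated chain carbon bound to an oxygen on an unsaturated carbon. Going by the values given here, no measured pair isolates this change. Compounds 2 and 3, which carry chlorine on that ring but also differ from compound 1 in the core and the aryl group, both give lower numbers than compound 1, which offers only an indirect hint.

Compound 4 is therefore expected to give 1500 nM in this assay, within 500 nM to 5000 nM. This estimate means a step of a 2.9-fold lower number from compound 1 to compound 4 (0.47 log units; beyond the scatter), a lower number expected with low confidence.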

Compound 4, half-maximal effective concentration: 1500 nM
Beside the measured number, compound 4's estimate shows no gap at the digits printed, and the stated range covers the measured number.
By their numbers in this assay, from the lowest: compounds 3, 2 and 4 (each within the scatter of the next, the first and the last beyond it); then compound 1.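

In this assay, for the compounds shown here, the change on the benzyloxy arm gives a 2.9-fold lower number from compound 1 to compound 4 (0.47 log units; beyond the scatter) and so provides the first reading of this position with everything else held fixed, as the earlier pair differed only in the aryl group on the core. On this shared core, 2,4-dichlorophenyl in place of 4-methoxyphenyl on a saturated chain carbon bound to an oxygen on an unsaturated carbon therefore goes with a modest step beyond the scatter, and the earlier indirect hint now has a direct pair behind it. Nothing measured here accounts for the size or direction of this step.

As far as these compounds go, whether 4-chlorophenyl or an unsubstituted phenyl at this place would give a number nearer that of compound 1 or that of compound 4 remains open. So does whether the same change would carry over to the core and aryl group of compound 2 or compound 3.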